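Changing one substituent on a ring carbon

The source may report more compounds than this note shows. Statements on the series, on what has been measured and on what is new or still open speak of the compounds shown alone.

Measured in a functional assay on A549 cells (Homo sapiens) for antiproliferative activity, read by MTT assay, with a stated time of 48 h; a lower number here means a stronger inhibitor, a higher number a weaker inhibitor:
Compound 1 `CC(C)=CCC[C@]1(C)/C=C/[C@@H](OC(=O)C=C(C)C)[C@](C)(O)/C=C/C(=O)/C(C(=O)O)=C\C1`: > 10000 nM (a limit)
Compound 2 `CO/N=C/C1=C/C[C@](C)(CCC=C(C)C)/C=C/[C@@H](OC(=O)C=C(C)C)[C@](C)(O)/C=C/C1=O`: 3470 nM

In this assay, going by the values given here, compound 2 gives 3470 nM, the only true number available so far. The one other result is the limit of > 10000 nM in this assay, at which 1 of the 2 values shown sits, and it belongs to compound 1 as a limit.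

Compound 3 `CC(C)=CCC[C@]1(C)/C=C/[C@@H](OC(=O)C=C(C)C)[C@](C)(O)/C=C/C(=O)/C(C(=O)N2CCCC2)=C\C1` has not yet been measured. Relative to compound 2, it carries (pyrrolidin-1-yl)carbonyl on the same double-bonded ring carbon of the shared core: a group of 7 heavy atoms (5 carbon, 1 nitrogen, 1 oxygen; one five-membered non-aromatic ring with 1 hetero atom) in place of a group of 4 heavy atoms (2 carbon, 1 nitrogen, 1 oxygen; no ring), on a double-bonded ring carbon.

Among the compounds with values here, only one measured step bears on this change, since it falls at the same ring carbon. This is an at least 2.8-fold lower number from compound 1 to compound 2 (0.45 log units; beyond the scatter), an at least modest step beyond the scatter. It shows that the substituent at this place can move the number in this assay, but it gives no direction for a new group, and it is a single step. The expectation is therefore no step beyond the scatter, with only a slight lean towards a higher number. The expected change is a 1.3-fold higher number from compound 2 to compound 3 (0.11 log units; within the scatter). For compound 3 the estimate is 4500 nM, with an expected range of 1500 nM to 15000 nM.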

Compound 3, half-maximal inhibitory concentration: 13000 nM
The estimate for compound 3 lay 2.9-fold (0.46 log units) below the measured number; measured number inside the range.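

In this assay this double-bonded ring carbon now has a step with a readable size and a direction: a 3.7-fold higher number from compound 2 to compound 3 (0.57 log units; beyond the scatter). The earlier step at this carbon started from a limit, whereas this one joins two true numbers, and it shows that (pyrrolidin-1-yl)carbonyl is not tolerated as well as the group of compound 2, with its 4 heavy atoms and no ring. Compound 1 is held only as a limit, > 10000 nM, so the step from compound 1 to compound 3 cannot be read, and the acid and the amide at this carbon cannot be ranked against each other.

The compounds shown leave open whether the higher number follows the pyrrolidine ring itself or the carbonyl that carries it, and a dimethylamino carbonyl or a methyl ester at the same carbon would be needed to separate the two. They also leave open whether any group at this place can bring a clearly lower number than compound 2, which gives 3470 nM.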